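Sulfonamide variation on the valine-leucinal scaffold

This account rests on a few compounds, and the source may have more. Where it says the series, first, only, none or still open, it means among the compounds named here.

Three peptidic aldehydes have been measured in an assay on isolated protein (Sus scrofa) for inhibition of Calpain-1 catalytic subunit (Homo sapiens); a higher number here means a weaker inhibitor, a lower number a stronger inhibitor. Compound 1 `CC(C)C[C@H](C=O)NC(=O)[C@H](C(C)C)N(C)S(=O)(=O)c1ccc(F)cc1` carries a 4-fluorophenylsulfonyl group on a methylated sulfonamide nitrogen and gives 21000 nM. Compound 2 `CC(C)C[C@H](C=O)NC(=O)[C@@H](NS(C)(=O)=O)C(C)C` keeps the same valine-leucinal backbone with a methanesulfonyl group and an unsubstituted sulfonamide nitrogen; in this assay compound 2 gives 830 nM. Compound 3 `CC(C)C[C@H](NS(=O)(=O)c1ccc(F)cc1)C(=O)N[C@@H](C=O)CC(C)C` pairs the 4-fluorophenylsulfonyl group with a leucine unit in place of valine and gives 130 nM.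

On these numbers compound 2 stands second highest of the three: compound 3 lies well below it, compound 1 far above it, and both gaps exceed the scatter. Going by the values given here, no step between measured compounds differs in a single place, so no single-point comparison is available.

Compound 4 `CC(C)C[C@H](C=O)NC(=O)[C@@H](NS(=O)(=O)c1ccc(Cl)cc1)C(C)C` is not yet measured. It differs from compound 2 as follows: 4-chlorophenyl in place of methyl on a sulfonyl sulfur. Among the measured compounds, the unmethylated aryl sulfonamide of compound 3 gives 130 nM, the lowest number of the set, whereas the methylated aryl sulfonamide of compound 1 gives 21000 nM. Compound 4 retains the free sulfonamide hydrogen, so a step downward is expected, a 5.5-fold lower number from compound 2 to compound 4 (0.74 log units; beyond the scatter), beyond the scatter. For compound 4 the estimated value in this assay is 150 nM, within a range from 40 nM to 600 nM.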

Compound 4, half-maximal inhibitory concentration: 31 nM
Compound 4: middle estimate off by 4.8-fold (0.68 log units), on the high side; measured number outside the range, below it.
By their numbers in this assay, from the lowest: compound 4; then compound 3; then compound 2; then compound 1.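

In this assay, going by these compounds alone, 4-chlorophenyl in place of methyl on a sulfonyl sulfur gives a 27-fold lower number from compound 2 to compound 4 (1.43 log units; beyond the scatter), the first step that differs in one place only. With the sulfonamide nitrogen unsubstituted and the valine-leucinal backbone unchanged, this position accepts a much larger group: a six-membered aromatic ring and a chlorine enter where a single carbon leaves, and the number falls rather than rises, by a large step well beyond the scatter. Nothing at hand bears on the reason for this step, which stands here as an observation only.

Going by these compounds, whether the step belongs to the aromatic ring, to the chlorine or to the size of the group stays open; an unsubstituted phenyl, a 4-methoxyphenyl or a longer chain such as n-butyl on the same sulfonyl sulfur would separate these readings. The compounds shown also give no single-place reading of chlorine against fluorine on the ring, of a methyl on the sulfonamide nitrogen, or of valine against leucine.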